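The compounds below may be only part of what the source reports. "The series", "measured", "known", "first", "only" and "open" are said of these compounds alone.

Measured in an assay on CHO-TREX cells for antagonist activity at transient receptor potential cation channel subfamily A member 1 (Homo sapiens), read by FLIPR and calcium flux, with a stated time of 10 min; on this read-out higher numbers stand for weaker inhibition and lower numbers for stronger inhibition:
compound 1 `COc1cc2[nH]ncc2cc1-c1ccccc1C(F)(F)F` — 26 nM
compound 2 `CCOc1cc2[nH]ncc2cc1-c1ccccc1C(F)(F)F` — 39 nM

Compound 2 is separated from compound 1 only by a 1.5-fold higher number from compound 1 to compound 2 (0.18 log units; within the scatter), so on the two numbers in hand the pair stand together. Compound 3 `N#Cc1cc2[nH]ncc2cc1-c1ccccc1C(F)(F)F` differs from compound 2 by cyano in place of ethoxy on an aromatic carbon. Going by the values given here, the single measured step varies the length of the oxygen-bound chain and does not bear directly on exchanging the ethoxy for a cyano group; there is no precedent in this set for that change. The step of a 1.5-fold higher number from compound 2 to compound 3 (0.19 log units; within the scatter) is therefore expected with low confidence, taken as roughly neutral with a broad range. Compound 3 is expected to give about 60 nM in this assay, between 12 nM and 300 nM.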

Compound 3, half-maximal inhibitory concentration: 129 nM
Compound 3: middle estimate off by 2.2-fold (0.33 log units), on the low side; measured number inside the range.
By their numbers in this assay, from the lowest: compounds 1 and 2 (each within the scatter of the next); then compound 3.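

In this assay, going by these compounds alone, this aromatic carbon, ortho to a large group, shows for the first time a change beyond the scatter: cyano gives weaker inhibition than ethoxy (a 3.3-fold higher number from compound 2 to compound 3 (0.52 log units; beyond the scatter)) and than methoxy (a 5.0-fold higher number from compound 1 to compound 3 (0.70 log units; beyond the scatter)). The position therefore does not accept every replacement of the oxygen-bound chain equally. Nothing measured here accounts for this difference.

From the compounds shown here alone, how an amine, a carboxylic acid or a longer oxygen-bound chain would read at this carbon remains open. So does whether any group here gives stronger inhibition than methoxy or ethoxy.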